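Furan-2-yl to 4-nitrophenyl: cytotoxicity working notes

The compounds below may be only part of what the source reports. "The series", "measured", "known", "first", "only" and "open" are said of these compounds alone.

The series shares one core, seen in compound 1 (`C=CCOc1cc(OC)c(C(=O)/C=C/C=C/c2ccccc2)c(OCC=C)c1`) and compound 2 (`C=CCOc1cc(OC)c(C(=O)/C=C/c2ccco2)c(OCC=C)c1`). In an ADME assay on Vero cells (Chlorocebus sabaeus) for cytotoxicity, read by MTT assay (on this read-out lower numbers stand for stronger inhibition and higher numbers for weaker inhibition), compound 1 has "not determined" (no result reported) as its entry. Among the compounds with values here, compound 2 gives 191000 nM and holds the only number, so it has no rank against another compound. Compound 3 (`C=CCOc1cc(OC)c(C(=O)/C=C/c2ccc([N+](=O)[O-])cc2)c(OCC=C)c1`) differs from it by 4-nitrophenyl in place of furan-2-yl on a double-bonded chain carbon bound to a double-bonded chain carbon in one place. No measured step sizes this change, and compound 2 at 191000 nM is the sole anchor. A modest move towards stronger inhibition is expected, with an estimated 1.9-fold lower number from compound 2 to compound 3 (0.28 log units; within the scatter) as the step. For compound 3 the estimate is 100000 nM within an expected range from 30000 nM to 250000 nM in this assay here.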

Compound 3, half-maximal inhibitory concentration: 12600 nM
The estimate for compound 3 lay 7.9-fold (0.90 log units) above the measured number; measured number outside the range, below it.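

The position on a double-bonded chain carbon bound to a double-bonded chain carbon responds clearly in this assay with a 15-fold lower number from compound 2 to compound 3 (1.18 log units; beyond the scatter) when 4-nitrophenyl replaces furan-2-yl, a large step beyond the scatter. Within the data shown here, this is the first sized change, and it holds for this one exchange only. Nothing at hand accounts for the step. Compound 1 has no number, so steps to it cannot be read. As far as these compounds go, whether the step follows the nitro group or the six-membered aromatic ring stays open, and an unsubstituted phenyl or a 4-aminophenyl at this place would separate the two.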